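Fluoro for trifluoromethoxy on the pendant phenyl

The source may hold more compounds than are shown below. What is called first, only, known or untested is meant among the compounds shown, and "the series" means these compounds.

Compound 1 `CCOc1cc(CN2CCC(NC(=O)c3cncc(C)c3)CC2)cc(OCC)c1F`: 2.9
Compound 2 `CCOc1cc(CN2CCC(NC(=O)c3cncc(C)c3)CC2)ccc1-c1ccc(F)cc1`: 4.1
Compound 3 `CCOc1cc(CN2CCC(NC(=O)c3cncc(C)c3)CC2)cc(OCC)c1-c1ccc(OC(F)(F)F)cc1`: > 4

Of the compounds shown here, three sharing one core have been measured in a physicochemical assay for lipophilicity, read by spectrophotometry, measured as octanol-water partition, at pH 7.4; on this read-out higher numbers stand for higher lipophilicity and lower numbers for lower lipophilicity. Compound 1, with fluoro on the aromatic carbon, gives 2.9. Compound 2, which carries a 4-fluorophenyl, gives 4.1. For compound 3 the value of > 4 is a limit of the assay and not a number, so compound 3 stands at the top of this set without a precise position, as it sits at the limit of > 4 in this assay, at which 1 of the 3 values shown sits. Among the measured compounds shown here, the one measured step, a number at least 1.10 log units higher from compound 1 to compound 3 (beyond the scatter), is large.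

Compound 4 `CCOc1cc(CN2CCC(NC(=O)c3cncc(C)c3)CC2)cc(OCC)c1-c1ccc(F)cc1` is reached from compound 3 by a single change, (fluoro in place of trifluoromethoxy on an aromatic carbon). The step from compound 1 to compound 3 bears on this change in reverse, since it replaced fluoro with 4-(trifluoromethoxy)phenyl, but it is confounded by the added ring, so only part of it can be expected to come back. The close relative compound 2, bearing 4-fluorophenyl, shows where a fluorophenyl compound on this core lands. Compound 4 is therefore expected to fall in this assay by a step that the limit leaves unreadable from compound 3 to compound 4, to an estimated 4.3, within 3.8 to 4.8, and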

Compound 4, distribution coefficient: 4.01
Beside the measured number, compound 4's estimate is 0.29 log units above it; measured number inside the range.
By their numbers in this assay, from the lowest: compound 1; then compounds 4 and 2 (each within the scatter of the next).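

In this assay, putting ethoxy in place of hydrogen on the aromatic carbon of the shared core leaves no step beyond the scatter when 4-fluorophenyl is present: a number 0.09 log units lower from compound 2 to compound 4 (within the scatter). The exchange of fluoro on the aromatic carbon for 4-fluorophenyl can now be given as a number, where the earlier exchange for 4-(trifluoromethoxy)phenyl ended at a limit, and it is large: a number 1.11 log units higher from compound 1 to compound 4 (beyond the scatter). For compound 3 the value > 4 is a limit and not a number, so the step from trifluoromethoxy to fluoro on the pendant phenyl cannot be read: the limit of > 4 in this assay, at which 1 of the 4 values shown sits.

As far as these compounds go, how far trifluoromethoxy and fluoro at this place stand apart in this assay therefore stays open, and a group such as chloro, methoxy, an amine or a carboxylic acid on the pendant phenyl would be needed to show how the read-out moves there on a readable scale. Also open, from the compounds shown here alone, is whether ethoxy in place of hydrogen stays within the scatter when the pendant phenyl carries 4-trifluoromethoxy or any group other than fluoro.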